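Aryl on the triazole nitrogen: expecting compound 4

The source may hold more compounds than are shown below. What is called first, only, known or untested is meant among the compounds shown, and "the series" means these compounds.

Of the compounds shown here, three sharing one core have been tested in a functional assay on HeLa cells (Homo sapiens) for inhibition, read by MTT assay, with a stated time of 24 h; on this read-out higher numbers stand for weaker inhibition and lower numbers for stronger inhibition. Compound 1 `CCCCCCCCn1cc(COC2(C(F)(F)F)Oc3ccccc3C=C2C(=O)OCC)nn1` carries an octyl chain on the triazole nitrogen; in this assay compound 1 gives only a limit, > 150000 nM, as noted in the limit of > 150000 nM in this assay, at which 1 of the 3 values shown sits. Compound 2 `CCOC(=O)C1=Cc2ccccc2OC1(OCc1cn(-c2ccc(F)c([N+](=O)[O-])c2)nn1)C(F)(F)F` gives 15600 nM, and compound 3 `CCOC(=O)C1=Cc2ccccc2OC1(OCc1cn(CC(=O)Nc2ccccc2F)nn1)C(F)(F)F` gives 49900 nM, which is the highest of the two real numbers, with compound 2 the nearer by a 3.2-fold higher number from compound 2 to compound 3 (0.50 log units; beyond the scatter). Replacing the chain of compound 1 gave an at least 9.6-fold lower number from compound 1 to compound 2 (0.98 log units; beyond the scatter) and an at least 3.0-fold lower number from compound 1 to compound 3 (0.47 log units; beyond the scatter), so both aryl-bearing groups worked better than the plain chain.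

Compound 4 `CCOC(=O)C1=Cc2ccccc2OC1(OCc1cn(-c2cccc(C(F)(F)F)c2)nn1)C(F)(F)F` differs from compound 3 by 3-(trifluoromethyl)phenyl in place of ((2-fluorophenyl)carbamoyl)methyl on an aromatic nitrogen. This brings an aromatic ring straight onto the ring nitrogen, as in compound 2. The step from compound 2 to compound 3 ran the other way, so the step back is expected to be about as large: a 2.8-fold lower number from compound 3 to compound 4 (0.44 log units; beyond the scatter). Compound 4 is therefore estimated at 18000 nM, within a range from 6000 nM to 55000 nM.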

Compound 4, half-maximal inhibitory concentration: > 150000 nM
Compound 4 ended at the assay's limit; the forecaster's own chance of this, stated with the estimate: 10%; middle value at least 8.3-fold (0.92 log units) away from the limit.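

An aromatic ring set straight on the aromatic nitrogen does not by itself secure inhibition: swapping the ring of compound 2 for 3-(trifluoromethyl)phenyl gives an at least 9.6-fold higher number from compound 2 to compound 4 (0.98 log units; beyond the scatter) in this series. Directly attached rings now fall on both sides of the ((2-fluorophenyl)carbamoyl)methyl group, with a 3.2-fold higher number from compound 2 to compound 3 (0.50 log units; beyond the scatter) on one side and an at least 3.0-fold higher number from compound 3 to compound 4 (0.47 log units; beyond the scatter) on the other, so what the ring carries matters as much as how it is attached. Compound 1 and compound 4 each give a limit rather than a number, so the step between them cannot be read: the limit of > 150000 nM in this assay, at which 2 of the 4 values shown sit.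

On these data alone, compound 2 and compound 4 differ in more than one ring substituent, so it stays open whether the nitro group or the fluorine accounts for the activity of compound 2. A 3-nitrophenyl or 4-fluorophenyl group on the same nitrogen would separate the two.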